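Shortening the ester-linked chain of a retinoid amide

The source may report more compounds than this note shows. Statements on the series, on what has been measured and on what is new or still open speak of the compounds shown alone.

Measured compounds in a functional assay on NB-4 cells (Homo sapiens) for inhibition, read by MTT assay, with a stated time of 48 h; on this read-out higher numbers stand for weaker inhibition and lower numbers for stronger inhibition:
- compound 1 `CCCC(CCC)C(=O)OCCCCOC(=O)c1ccc(C(=O)Nc2ccc3c(c2)C(C)(C)CCC3(C)C)cc1`: compound 1 gives > 1000000 nM
- compound 2 `C=C(c1ccc(C(=O)OCCOC(=O)c2ccc(C(=O)Nc3ccc4c(c3)C(C)(C)CCC4(C)C)cc2)cc1)c1cc2c(cc1C)C(C)(C)CCC2(C)C`: compound 2 gives > 1000000 nM

Both values are limits of this assay rather than numbers. For compound 1 the value > 1000000 nM is such a limit, so its place among the numbers shown cannot be fixed more closely than the limit of > 1000000 nM in this assay, at which 2 of the 2 values shown sit. For compound 2 the value > 1000000 nM is likewise a limit. Within the data shown here, no step between two measured compounds with a single change exists here, so the two values show only that neither compound reached a measurable half-maximal inhibitory concentration.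

The unmeasured compound 3 `CCCC(CCC)C(=O)OCCOC(=O)c1ccc(C(=O)Nc2ccc3c(c2)C(C)(C)CCC3(C)C)cc1` differs from compound 1 by ((1-propylbutyl)carbonyl)oxy in place of 2-(((1-propylbutyl)carbonyl)oxy)ethyl on a saturated chain carbon, two bonds along the chain from an oxygen next to a carbonyl group. Since compound 1 sits at the limit, the step is expected to be none beyond the scatter, with compound 3 most likely also returning a limit in this assay. The expected step from compound 1 to compound 3 is a number no higher from compound 1 to compound 3 (the limit leaves the size open). Compound 3 is therefore estimated at 1000000 nM, with a range from 300000 nM to 3000000 nM.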

Compound 3, half-maximal inhibitory concentration: > 1000000 nM
Compound 3 was reported as a limit (the forecaster's own chance of this, stated with the estimate: 80%); the middle value lies on the limit itself.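

In this assay compound 3 gives > 1000000 nM, which is a limit and not a number. Compound 1 also sits at a limit, so no step from compound 1 to compound 3 can be read: the limit of > 1000000 nM in this assay, at which 3 of the 3 values shown sit.

The compounds shown leave open whether changing this chain alters inhibition at all; none of them gives a number.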